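This account rests on a few compounds, and the source may have more. Where it says the series, first, only, none or still open, it means among the compounds named here.

Of the compounds shown here, three have so far been tested in a toxicity assay on THP-1 cells (Homo sapiens) for inhibition; a lower number here means that less compound is tolerated, a higher number that more compound is tolerated. Compound 1 `COc1ccccc1-c1cnc(NC(=O)c2ccc(F)cc2)n1C` gives > 100000 nM, which is a limit of the assay rather than a number. Compound 2 `COc1ccc(-c2cnc(NC(=O)C3CCCCC3)n2C)cc1` gives > 100000 nM, again a limit. Compound 3 `Cc1ccccc1-c1cnc(NC(=O)c2ccc(F)cc2)n1C` gives > 50000 nM, also a limit. Among the measured compounds shown here, the single change between measured compounds, a step that the two limits leave unreadable from compound 1 to compound 3, is not readable, with both of its ends sitting at limits. Compound 2 therefore stands at the limit of > 100000 nM in this assay, at which 2 of the 3 values shown sit. Compound 3 sits at the limit of > 50000 nM in this assay, at which 1 of the 3 values shown sits. Compound 4 `COc1ccc(-c2cnc(NC(=O)C3CCCC3)n2C)cc1` has not yet been measured. It differs from compound 2 by cyclopentyl in place of cyclohexyl on a carbonyl carbon. For the measured compounds named here, no measured step bears on this change, and the one measured step, from compound 1 to compound 3, gives no readable size. With nothing pointing to tolerance ending below the limit, compound 4 is expected to remain there, and the expected step that the limit leaves unreadable from compound 2 to compound 4 is none beyond the scatter. The estimate for compound 4 is 200000 nM, with a range from 100000 nM to 500000 nM.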

Compound 4, half-maximal cytotoxic concentration: > 100000 nM
Compound 4 gave a limit, no number (the forecaster's own chance of this, stated with the estimate: 85%); the middle value does not contradict the limit.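

Compound 4, like compound 2, sits at a limit of the assay in this assay, so the step between compound 2 and compound 4 cannot be read. The compounds shown leave open at what concentration any of them would reach half-maximal cytotoxicity, and whether cyclopentyl and cyclohexyl differ at all in tolerance.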